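The compounds below may be only part of what the source reports. "The series", "measured", "known", "first", "only" and "open" are said of these compounds alone.

Of the compounds shown here, three share a common core and have been tested in a functional assay on Shh Light II cells (Mus musculus) for inhibition, read by a luciferase reporter; on this read-out lower numbers stand for stronger inhibition and higher numbers for weaker inhibition. Compound 1 `O=C(Nc1cccc2cccnc12)N1CCC(c2nc(-c3ccc4ccccc4n3)no2)CC1` gives 1400 nM, and compound 2 `O=C(Nc1cccnc1Cl)N1CCC(c2nc(-c3ccc4ccccc4n3)no2)CC1` gives 1600 nM; the step of a 1.1-fold higher number from compound 1 to compound 2 (0.06 log units; within the scatter) is within the scatter. Compound 3 `O=C(OC1CCCCC1)N1CCC(c2nc(-c3ccc4ccccc4n3)no2)CC1` gives 580 nM, which is the lowest number of the three: the step of a 2.4-fold lower number from compound 1 to compound 3 (0.38 log units; beyond the scatter) and the step of a 2.8-fold lower number from compound 2 to compound 3 (0.44 log units; beyond the scatter) are both beyond the scatter, though modest.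

Compound 4 `O=C(N1CCC(c2nc(-c3ccc4ccccc4n3)no2)CC1)N1CCCc2ccccc21` is the next compound to be measured. It differs from compound 3 in one place: 1,2,3,4-tetrahydroquinolin-1-yl in place of cyclohexyloxy on a carbonyl carbon. For the measured compounds named here, no measured step pairs a cyclohexyloxy group directly against a 1,2,3,4-tetrahydroquinolin-1-yl group. The two steps that bear on it, from compound 1 and compound 2 to compound 3, show that exchanging an arylamino substituent on the carbonyl carbon for cyclohexyloxy lowered the number modestly. The group entering in compound 4 is neither an arylamino nor an alkoxy group, so that evidence is indirect, and the expectation for compound 4 is a step of a 1.3-fold higher number from compound 3 to compound 4 (0.11 log units; within the scatter) that stays within the scatter, with the number perhaps drifting slightly higher. On that basis compound 4 is estimated at 750 nM, with a range from 300 nM to 1800 nM.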

Compound 4, half-maximal inhibitory concentration: 2300 nM
For compound 4 the middle estimate is 3.1-fold (0.49 log units) below the measured one; the measured number lies above the stated range.
By their numbers in this assay, from the lowest: compound 3; then compounds 1, 2 and 4 (each within the scatter of the next).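

The change to 1,2,3,4-tetrahydroquinolin-1-yl on this carbonyl carbon gives up the lower number of compound 3 in this assay, with a 4.0-fold higher number from compound 3 to compound 4 (0.60 log units; beyond the scatter) as a modest step, so a ring group attached through nitrogen does not stand in for cyclohexyloxy here. The new group also does not separate from the two arylamino groups, since a 1.4-fold higher number from compound 2 to compound 4 (0.16 log units; within the scatter) and a 1.6-fold higher number from compound 1 to compound 4 (0.22 log units; within the scatter) are both within the scatter, which leaves the three nitrogen-attached groups together and compound 3 alone apart, even though neither cyclohexyloxy nor the entering group counts a hydrogen-bond donor, so the absence of the amide hydrogen does not by itself go with the lower number. No measurement at hand explains this step.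

As far as these compounds go, whether the lower number of compound 3 goes with the oxygen on the carbonyl carbon or with the saturated carbon ring stays open, and a phenoxy or a cyclohexylamino group in this place would separate the two. From the compounds shown here alone, it is also open whether the aromatic ring of the entering group matters, which a piperidin-1-yl group in the same place would address.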